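Swapping the Ring on the Sulfonyl Group

A few compounds are considered here, and "the series" means these few. Any claim that something is new, unique, unknown or untested is made for them only; others in the source may bear on it.

Of the compounds shown here, three have been tested in an assay for inhibition of Nicotinamide phosphoribosyltransferase (Homo sapiens), read by mass spectrometry, with stated times of 15 min and 30 min; a lower number here means a stronger inhibitor, a higher number a weaker inhibitor. Compound 1 `O=C(NCc1ccc(S(=O)(=O)c2ccccc2)cc1)c1cc2ncccc2s1` gives 400 nM. Compound 3 `O=C(NCc1ccc(S(=O)(=O)N2CCCCC2)cc1)c1cc2ccncc2o1` gives 40 nM. Compound 2 `Cc1cccc(S(=O)(=O)c2ccc(CNC(=O)c3cc4cnccc4[nH]3)cc2)c1` gives 8 nM, the lowest of the three numbers; its gap to compound 3 and its larger gap to compound 1 both lie beyond the usual scatter, so compound 2 is the strongest inhibitor of the three. These compounds differ from one another in more than one place at once, so none of the gaps can be tied to a single structural change.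

Compound 4 `O=C(NCc1ccc(S(=O)(=O)c2ccc(F)cc2)cc1)c1cc2cnccc2[nH]1` has not yet been measured. It is built from compound 2 by a single change: 4-fluorophenyl in place of 3-methylphenyl on a sulfonyl sulfur. One aromatic ring is exchanged for a closely related one, and the rest of the molecule is kept. Going by the values given here, no measured pair shows this kind of exchange on its own, so the size of the step is uncertain. The expected step is a 1.9-fold higher number from compound 2 to compound 4 (0.27 log units; within the scatter), a modest move toward a weaker inhibitor if any, since the measured compounds offer no reason to expect a large change. Compound 4 is therefore estimated at 15 nM, within a range from 5 nM to 50 nM.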

Compound 4, half-maximal inhibitory concentration: 17 nM
The estimate for compound 4 lay 1.1-fold (0.05 log units) below the measured number; measured number inside the range.
By their numbers in this assay, from the lowest: compound 2; then compound 4; then compound 3; then compound 1.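

In this assay, going by these compounds alone, putting 4-fluorophenyl in place of 3-methylphenyl on a sulfonyl sulfur gives a 2.1-fold higher number from compound 2 to compound 4 (0.33 log units; beyond the scatter) and is the first comparison here in which only this one group differs, so the gap can be tied to that exchange alone. The step is modest but lies beyond the usual scatter, which shows that this position responds to even a close swap: the two groups match in heavy-atom count, each has one six-membered aromatic ring of carbon only, and neither has hydrogen-bond donors, hydrogen-bond acceptors or a net charge. Nothing among the available data explains why the number moves.

This single pair cannot show whether the step comes from losing the methyl, gaining the fluorine or the different placement of these groups on the ring, and it cannot show whether the same exchange would have a similar effect on another core. It also leaves open how the number would respond to a larger or quite different ring substituent, such as an amine, a carboxylic acid or a longer alkyl chain.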